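This account rests on a few compounds, and the source may have more. Where it says the series, first, only, none or still open, it means among the compounds named here.

Compound 1 has the structure `Cc1c(/C=N\O)cc(-c2ccc(S(C)(=O)=O)cc2)n1-c1ccc(F)cc1`. In an assay on J774 cells for inhibition of prostaglandin G/H synthase 1 (Mus musculus), read by immunoassay, with stated times of 15 min and 30 min (a lower number here means a stronger inhibitor, a higher number a weaker inhibitor), compound 1 gives > 10000 nM, which is a limit of the assay rather than a number.

Compound 2 has the structure `Cc1c(/C=N\O)cc(-c2ccc(S(C)(=O)=O)cc2)n1-c1ccccc1`. In this assay compound 2 gives > 10000 nM, again only a limit.

Compound 3 has the structure `Cc1c(C#N)cc(-c2ccc(S(C)(=O)=O)cc2)n1-c1cccc(F)c1`. In this assay compound 3 gives > 10000 nM, also a limit.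

All three measured compounds share a sulfonyl-bearing aryl group on a common heterocyclic core, and the difference between the core of compound 2 and the core of compound 3 is not broken down here. The not yet measured compound 4 has the structure `Cc1c(C#N)cc(-c2ccc(S(C)(=O)=O)cc2)n1-c1ccc(F)c(F)c1`.

From compound 2 to compound 1 the change is fluoro in place of hydrogen on an aromatic carbon. The step it made, a step that the two limits leave unreadable from compound 2 to compound 1, cannot be read in size, because both values are limits; this rests on (the limit of > 10000 nM in this assay, at which 3 of the 3 values shown sit).

From compound 3 to compound 4 the change is fluoro in place of hydrogen on an aromatic carbon. Among the measured compounds shown here, it is the same kind of change as the one from compound 2 to compound 1, not the same: in compound 4 the entering fluoro sits ortho to a fluoro group and para to a large group, whereas in compound 1 it sits para to a large group only.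

For compound 4 the expected step is a step that the limit leaves unreadable from compound 3 to compound 4, resting on compound 3 at > 10000 nM and on the unreadable step that the two limits leave unreadable from compound 2 to compound 1. Compound 4 is therefore estimated to lie at 15000 nM, between 4000 nM and 60000 nM, most likely again reported as a limit.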

Compound 4, half-maximal inhibitory concentration: > 10000 nM
Compound 4: a limit, no number; the forecaster's own chance of this, stated with the estimate: 80%; the middle value does not contradict the limit.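

In this assay compound 4 gives > 10000 nM as a limit, not a number. No size can be read for the step from compound 3 to compound 4, because both compounds sit at a limit: the limit of > 10000 nM in this assay, at which 4 of the 4 values shown sit.

The compounds shown leave open what number any of the four would reach in this assay and whether an entering fluoro changes that number at all.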